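The source may report more compounds than this note shows. Statements on the series, on what has been measured and on what is new or still open speak of the compounds shown alone.

Measured compounds:
- compound 1, `O=C(NCN1CCC(c2cccc[n+]2[O-])CC1)c1ccccc1`: 532 nM
- compound 2, `Cc1cccc(NC(=O)CN2CCC(c3ccc(O)cn3)CC2)c1`: 3.8 nM
- compound 3, `Cc1cc(Cl)cc(C)c1NC(=O)CN1CCC(c2ccccn2)CC1`: 240 nM

Working notes on the series. In a functional assay on HEK293 cells for agonist activity at D(4) dopamine receptor (Homo sapiens), read by FLIPR (a lower number here means that less compound is needed, a higher number that more compound is needed for the effect), compound 1 gives 532 nM, the highest number of the three measured compounds. Compound 3, the nearest, gives 240 nM, and that gap is beyond the scatter. Compound 2 sits far off with 3.8 nM. Among the compounds with values here, compound 2 and compound 3 are not single-point changes from compound 1, so no step between measured compounds is available to guide the next one.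

The unmeasured compound is compound 4, `O=C(NCN1CCC(c2cccc[n+]2[O-])CC1)c1cc(Cl)cc(Cl)c1`. It differs from compound 1 in one place: 3,5-dichlorophenyl in place of phenyl on a carbonyl carbon. Within the data shown here, nothing among the measured compounds varies this position alone, so the direction of the step is open. The expectation is that compound 4 stays close to compound 1, with the step of a 1.5-fold lower number from compound 1 to compound 4 (0.18 log units; within the scatter) expected to be small, possibly not beyond the scatter, and a wide range allowed. Compound 4 is estimated at 350 nM, between 80 nM and 1600 nM.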

Compound 4, half-maximal effective concentration: 45 nM
Compound 4: middle estimate off by 7.8-fold (0.89 log units), on the high side; the measured number lies below the stated range.
By their numbers in this assay, from the lowest: compound 2; then compound 4; then compound 3; then compound 1.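

In this assay, the group on the carbonyl carbon proves to be a place that strongly moves the number: 3,5-dichlorophenyl in place of phenyl gives a 12-fold lower number from compound 1 to compound 4 (1.07 log units; beyond the scatter), and the rest of the structure stays unchanged. Within the data shown here, this is the first single-place change, so it isolates the effect of this group in a way the earlier compounds could not. No measurement on hand accounts for the size of this step.

The compounds shown leave open whether one chlorine on the phenyl would give part or all of this step, or whether two methyl or two methoxy groups in place of the chlorines would do the same. Going by these compounds, it also remains open whether the same exchange would move the number on a different core.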